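Methoxy in place of ethyl on the carboxy compound

This account rests on a few compounds, and the source may have more. Where it says the series, first, only, none or still open, it means among the compounds named here.

In a functional assay on Hep 3B2 cells (Homo sapiens) for antiproliferative activity, read by MTT assay, with a stated time of 24 h (a higher number here means a weaker inhibitor, a lower number a stronger inhibitor), compound 1 (`CCc1ccc2nc(C(=O)Nc3c(F)cc(-c4cccc(F)c4)cc3F)c(C)c(O)c2c1`) gives 15800 nM. In this assay compound 3 (`CCc1ccc2nc(C(=O)Nc3c(F)cc(-c4cccc(F)c4)cc3F)c(C)c(C(=O)O)c2c1`) gives 16900 nM, and that value stands level with compound 1: the step is a 1.1-fold higher number from compound 1 to compound 3 (0.03 log units; within the scatter). In this assay compound 2 (`CCOc1ccc2nc(C(=O)Nc3c(F)cc(-c4cccc(F)c4)cc3F)c(C)c(O)c2c1`) gives > 100000 nM, which is a limit of the assay and not a number.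

Compound 4 (`COc1ccc2nc(C(=O)Nc3c(F)cc(-c4cccc(F)c4)cc3F)c(C)c(C(=O)O)c2c1`) carries methoxy in place of ethyl on an aromatic carbon of compound 3: methoxy in place of ethyl on an aromatic carbon.

Within the data shown here, no methoxy compound has a measured value yet. The nearest measured change is ethoxy in place of ethyl on an aromatic carbon, which gave an at least 6.3-fold higher number from compound 1 to compound 2 (0.80 log units; beyond the scatter). That step is a bound with no upper end, as it ends at the limit of > 100000 nM in this assay, at which 1 of the 3 values shown sits. Carboxy in place of hydroxy on an aromatic carbon made no difference beyond the scatter, as shown by a 1.1-fold higher number from compound 1 to compound 3 (0.03 log units; within the scatter), so the ethoxy result is expected to carry over to the carboxy compounds, though methoxy may not follow ethoxy in full. A move towards a higher number in this assay is therefore expected, of modest size or more.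

The expected change is a 2.7-fold higher number from compound 3 to compound 4 (0.43 log units; beyond the scatter).

For compound 4 the estimated value is 45000 nM, with an expected range of 14000 nM to 100000 nM.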

Compound 4, half-maximal inhibitory concentration: 14300 nM
Estimate against measurement, compound 4: 3.1-fold (0.50 log units) above; the measured number falls inside the stated range.
By their numbers in this assay, from the lowest: compounds 4, 1 and 3 (each within the scatter of the next). At a limit, above all of these: compound 2.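

In this assay, methoxy in place of ethyl on the carboxy compound gives a 1.2-fold lower number from compound 3 to compound 4 (0.07 log units; within the scatter), the first step shown that puts an oxygen on this aromatic carbon with no change beyond the scatter. On the carboxy compound, then, the ethyl at this position can give way to a methoxy group of the same heavy-atom count, with 1 hydrogen-bond acceptor in place of 0, and the number stays within the scatter. The large step seen with ethoxy, an at least 6.3-fold higher number from compound 1 to compound 2 (0.80 log units; beyond the scatter), therefore does not follow from an oxygen on this carbon alone, and its size remains a bound: the limit of > 100000 nM in this assay, at which 1 of the 4 values shown sits.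

Still open is whether that step belongs to the ethoxy group itself or to the hydroxy compounds, as the series shown gives neither ethoxy on the carboxy compound nor methoxy on the hydroxy compound. Also open, as far as these compounds go, is how far this position tolerates other groups on the carboxy compound, such as a longer chain like propoxy or an amine.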